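This account rests on a few compounds, and the source may have more. Where it says the series, first, only, none or still open, it means among the compounds named here.

For the measured compounds named here, compound 3 `O=S(=O)(NCCCCCCNCc1ccc(Br)cc1)c1c(Cl)cccc1Cl` carries the highest of the three numbers so far, although its steps to the others stay within the scatter: in a functional assay on MIA PaCa-2 cells (Homo sapiens) for inhibition, read by MTT assay, with a stated time of 72 h (a lower number here means a stronger inhibitor of growth, a higher number a weaker inhibitor of growth), compound 3 gives 14700 nM. Compound 1 `O=S(=O)(NCCCCCCNCc1ccc(Br)cc1)c1ccc2c(c1)OCC2` in this assay gives 13000 nM, and compound 2 `O=S(=O)(NCCCCCCNCc1ccc(Br)cc1)c1ccccc1F` in this assay gives 13300 nM. The steps among them, a 1.0-fold higher number from compound 1 to compound 2 (0.01 log units; within the scatter), a 1.1-fold higher number from compound 1 to compound 3 (0.05 log units; within the scatter) and a 1.1-fold higher number from compound 2 to compound 3 (0.04 log units; within the scatter), all lie within the scatter, even though each exchanges the whole group on the sulfonyl sulfur. Compound 4 `O=S(=O)(NCCCCCCNCc1ccc(Br)cc1)c1ccc2ccsc2c1` continues the same kind of exchange: 1-benzothiophen-6-yl in place of 2,6-dichlorophenyl on a sulfonyl sulfur. All three measured steps bear on it, since each of them also changed only the group on the sulfonyl sulfur and none moved the number beyond the scatter; the exchange in a 1.1-fold higher number from compound 1 to compound 3 (0.05 log units; within the scatter) also involves the 2,6-dichlorophenyl and is the nearest case. Compound 4 is therefore expected to stay close to its precursor, the expected step being a 1.1-fold lower number from compound 3 to compound 4 (0.02 log units; within the scatter). The estimate for compound 4 is 14000 nM, with a range from 6000 nM to 32000 nM.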

Compound 4, concentration for 50% growth inhibition: 6000 nM
Beside the measured number, compound 4's estimate is 2.3-fold (0.37 log units) above it; the measured number falls inside the stated range.
By their numbers in this assay, from the lowest: compound 4; then compounds 1, 2 and 3 (each within the scatter of the next).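

Until this point, no exchange on the sulfonyl sulfur in this assay had moved the number beyond the scatter, but 1-benzothiophen-6-yl does so against all three earlier groups, with a 2.5-fold lower number from compound 3 to compound 4 (0.39 log units; beyond the scatter), a 2.2-fold lower number from compound 2 to compound 4 (0.35 log units; beyond the scatter) and a 2.2-fold lower number from compound 1 to compound 4 (0.34 log units; beyond the scatter). A second ring alone does not account for this, since compound 1 also carries two rings and its group has the same count of heavy atoms, yet compound 1 stays within the scatter of compound 2 and compound 3, which carry one ring each. No measurement shown here explains the shift.

Still open, on these data alone, is whether the lower number depends on the ring sulfur, which 1-benzofuran-6-yl, with oxygen in its place, or naphthalen-2-yl could test. Also open, as far as these compounds go, is how an amine or a carboxylic acid on the 1-benzothiophen-6-yl group would change the number.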